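The source may hold more compounds than are shown below. What is called first, only, known or untested is meant among the compounds shown, and "the series" means these compounds.

In a functional assay on A549 cells (Homo sapiens) for cytotoxicity, read by MTT assay, with a stated time of 72 h (on this read-out higher numbers stand for weaker inhibition and lower numbers for stronger inhibition), two compounds sharing one core have been measured so far. Compound 1 `O=C(CN1CCN(c2nnc(Cc3ccccc3)c3ccccc23)CC1)Nc1ccc(Br)cc1` gives 2000 nM, and compound 2 `Cc1cccc(Cl)c1NC(=O)CN1CCN(c2nnc(Cc3ccccc3)c3ccccc23)CC1` gives 7420 nM, the higher of the two numbers and so the weaker inhibition. Compound 3 `O=C(CN1CCN(c2nnc(Cc3ccccc3)c3ccccc23)CC1)Nc1cc(C(F)(F)F)ccc1Cl` has not yet been measured. It carries 2-chloro-5-(trifluoromethyl)phenyl in place of 2-chloro-6-methylphenyl on an amide-type nitrogen, (2-chloro-5-(trifluoromethyl)phenyl in place of 2-chloro-6-methylphenyl on an amide-type nitrogen). Within the data shown here, only one measured step bears on this change, a swap at that same place: a 3.7-fold higher number from compound 1 to compound 2 (0.57 log units; beyond the scatter), which is modest but beyond the scatter. Among the measured compounds shown here, compound 2, at 7420 nM, holds the higher of only two numbers, so a modest move toward a lower number is the more likely outcome in this assay, though a single step is thin evidence. The expected change is a 2.1-fold lower number from compound 2 to compound 3 (0.33 log units; beyond the scatter). Compound 3 is estimated at 3500 nM, with an expected range of 1200 nM to 10000 nM.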

Compound 3, half-maximal inhibitory concentration: 89000 nM
For compound 3 the middle estimate is 25-fold (1.41 log units) below the measured one; the measured number lies above the stated range.
By their numbers in this assay, from the lowest: compound 1; then compound 2; then compound 3.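

In this assay, among these compounds, the group on the amide-type nitrogen proves able to move the number much further than the one earlier step suggested: 2-chloro-5-(trifluoromethyl)phenyl in place of 2-chloro-6-methylphenyl gives a 12-fold higher number from compound 2 to compound 3 (1.08 log units; beyond the scatter) and, set against 4-bromophenyl, gives a 45-fold higher number from compound 1 to compound 3 (1.65 log units; beyond the scatter). Both steps are large, so with the shared core unchanged, this one position alone spans a wide range of cytotoxic strength among these three compounds. Nothing measured here accounts for the sharp loss of inhibition.

Compound 3 lacks the methyl of compound 2 and carries a trifluoromethyl that compound 2 does not have. The compounds shown cannot separate these two changes. Also open, from the compounds shown here alone, is how a phenyl ring carrying an amine or a carboxylic acid would read at this place.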